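Indolyl to dichlorophenyl in a series without cytotoxic readings

This account rests on a few compounds, and the source may have more. Where it says the series, first, only, none or still open, it means among the compounds named here.

Measured compounds:
- compound 1 `CC(C)N(Cc1cccc(OCCCCCC(=O)O)c1)C(=O)c1ccccc1` — in an ADME assay on HEK293 cells (Homo sapiens) for cytotoxicity, read by CellTiter-Glo and resazurin assay, with a stated time of 72 h (a lower number here means that less compound is needed, a higher number that more compound is needed for the effect), compound 1 gives > 26000 nM, a limit of the assay.
- compound 2 `CC(C)N(Cc1cccc(OCCCCCC(=O)O)c1)C(=O)c1ccc(-c2ccc3[nH]ccc3c2)cc1` — in this assay compound 2 gives > 26000 nM, again a limit.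
- compound 3 `CC(C)N(Cc1cccc(OCCCCCC(=O)O)c1)C(=O)c1ccc(-c2cc3ccccc3n2S(=O)(=O)c2ccccc2)cc1` — in this assay compound 3 gives > 26000 nM, also a limit.

Compound 2 therefore stands at a limit in this assay rather than at a number, and the two further values shown sit at that same limit (the limit of > 26000 nM in this assay, at which 3 of the 3 values shown sit). The step to the new compound 4 `CC(C)N(Cc1cccc(OCCCCCC(=O)O)c1)C(=O)c1ccc(-c2ccc(Cl)c(Cl)c2)cc1` is 3,4-dichlorophenyl in place of 1H-indol-5-yl on an aromatic carbon. Among the compounds with values here, only one measured step touches the same place on the shared core: a step that the two limits leave unreadable from compound 1 to compound 2. Since both ends of that step are limits, its size cannot be read, and it gives no direction. Nothing in the measured values points to a step beyond the scatter in this assay; all three compounds, compound 1, compound 2 and compound 3, return the same limit. Compound 4 is therefore expected to sit at the limit too, with an expected step that the limit leaves unreadable from compound 2 to compound 4 that amounts to no change. The estimate for compound 4 is 30000 nM, in the range 15000 nM to 60000 nM.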

Compound 4, half-maximal effective concentration: > 26000 nM
Compound 4: only a limit was reported; the forecaster's own chance of this, stated with the estimate: 85%; the middle value is on the limit's open side.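

In this assay compound 4 gives > 26000 nM, which is a limit and not a number. The steps from compound 1 and compound 2 to compound 4 therefore cannot be read. The compounds shown leave open whether any of them has a measurable half-maximal effective concentration in this assay: the limit of > 26000 nM in this assay, at which 4 of the 4 values shown sit.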